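Swapping hydrogen for acetyl on the ring of compound 1

The compounds below may be only part of what the source reports. "The series", "measured", "known", "first", "only" and "open" are said of these compounds alone.

For the measured compounds named here, compound 1 `N#CC1CN1C(=O)Nc1ccccc1` is the anchor: in a functional assay on WiDr cells (Homo sapiens) for inhibition (a higher number here means a weaker inhibitor, a lower number a stronger inhibitor), compound 1 gives 12000 nM, the only plain number in this set. Compound 2 `N#CC1CN1C(=O)Nc1ccc(S(N)(=O)=O)cc1` carries a sulfamoyl group instead; in this assay compound 2 gives > 38000 nM, which is a limit of the assay rather than a number. The step of an at least 3.1-fold higher number from compound 1 to compound 2 (0.50 log units; beyond the scatter) runs toward weaker inhibition. Compound 3 `CC(=O)c1cccc(NC(=O)N2CC2C#N)c1` differs from compound 1 by acetyl in place of hydrogen on an aromatic carbon. Going by the values given here, that earlier step is the only guide, so the number for compound 3 is expected to rise, the estimated step of a 1.8-fold higher number from compound 1 to compound 3 (0.26 log units; within the scatter) pointing the same way. Compound 3 is therefore estimated at 22000 nM, most likely between 8000 nM and 60000 nM.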

Compound 3, half-maximal inhibitory concentration: 9000 nM
The estimate for compound 3 lay 2.4-fold (0.39 log units) above the measured number; the range from low to high includes it.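

In this assay, acetyl on an aromatic carbon, meta to a group of 8 heavy atoms, gives a 1.3-fold lower number from compound 1 to compound 3 (0.12 log units; within the scatter). A group added to the ring therefore need not bring the weaker inhibition seen with the sulfamoyl group of compound 2; at this position, acetyl leaves the read-out indistinguishable from that of compound 1. Nothing given here explains why the two groups differ. As far as these compounds go, whether an amine or a carboxylic acid at this position would behave like acetyl remains open. So does the effect of acetyl elsewhere on the ring.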